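Swapping a pyridine for a methylphenyl on a sulfonamide core

This account rests on a few compounds, and the source may have more. Where it says the series, first, only, none or still open, it means among the compounds named here.

Compound 1 `COc1ccc(Cl)cc1S(=O)(=O)Nc1cncc(C(N)=O)c1`: 16 nM
Compound 2 `COc1ccc(Cl)cc1S(=O)(=O)Nc1cncc(-c2ccncc2)c1`: 73 nM

In an assay on isolated protein for inhibition of alkaline phosphatase, tissue-nonspecific isozyme (Homo sapiens) (on this read-out higher numbers stand for weaker inhibition and lower numbers for stronger inhibition), compound 2 stands at the higher of the two numbers; compound 1 sits below it by a 4.6-fold higher number from compound 1 to compound 2 (0.66 log units; beyond the scatter). Compound 3 `COc1ccc(Cl)cc1S(=O)(=O)Nc1cncc(-c2ccc(C)cc2)c1` differs from compound 2 by 4-methylphenyl in place of pyridin-4-yl on an aromatic carbon. Within the data shown here, only the step from compound 1 to compound 2 touches this position, and it showed a modest weakening; it does not directly test losing the ring nitrogen. A further modest weakening is therefore expected, roughly a 2.1-fold higher number from compound 2 to compound 3 (0.31 log units; beyond the scatter). Compound 3 is estimated at 150 nM, within 50 nM to 500 nM.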

Compound 3, half-maximal inhibitory concentration: 147 nM
The estimate for compound 3 lay 1.0-fold (0.01 log units) above the measured number, and the stated range covers the measured number.
By their numbers in this assay, from the lowest: compound 1; then compounds 2 and 3 (each within the scatter of the next).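

Trading pyridin-4-yl for 4-methylphenyl removes the ring nitrogen, and with it the group's hydrogen-bond acceptor, yet in this assay this swap gives a 2.0-fold higher number from compound 2 to compound 3 (0.30 log units; within the scatter), so this position shows no clear penalty for losing that nitrogen. The carbamoyl group still stands clearly apart, as putting 4-methylphenyl in its place gives a 9.2-fold higher number from compound 1 to compound 3 (0.96 log units; beyond the scatter). No supporting data explain these differences.

The effects of removing the ring nitrogen and adding the methyl remain unseparated, which a plain phenyl could address. As far as these compounds go, whether an amine or a carboxylic acid here could match carbamoyl also remains open.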